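Amino in place of hydroxy on a saturated chain carbon

The source may report more compounds than this note shows. Statements on the series, on what has been measured and on what is new or still open speak of the compounds shown alone.

In a functional assay on A549 cells (Homo sapiens) for antiproliferative activity, read by MTT assay, with a stated time of 48 h (a lower number here means a stronger inhibitor, a higher number a weaker inhibitor), compound 1 `COc1ccc(C(=O)c2ccc(OC)c3c2C=CC(C)(C)O3)c(NC(=O)CBr)c1` gives 2460 nM and compound 2 `COc1ccc(C(=O)c2ccc(OC)c3c2C=CC(C)(C)O3)c(NC(=O)CO)c1` gives 100 nM as the lower of the two numbers. The change to compound 3 `COc1ccc(C(=O)c2ccc(OC)c3c2C=CC(C)(C)O3)c(NC(=O)CN)c1` is amino in place of hydroxy on a saturated chain carbon bound to a carbonyl carbon and puts amino in place of hydroxy on a saturated chain carbon bound to a carbonyl carbon. Among the compounds with values here, the only measured step at this place is a 25-fold lower number from compound 1 to compound 2 (1.39 log units; beyond the scatter) and it is large, but it replaced bromo and does not compare amino with hydroxy. Within the data shown here, with only that step to go on, the expected change is a 1.6-fold higher number from compound 2 to compound 3 (0.20 log units; within the scatter) and amounts to a small rise at most. For compound 3 the estimated value is 160 nM with an expected range from 40 nM to 640 nM in this measurement.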

Compound 3, half-maximal inhibitory concentration: 420 nM
Compound 3: the middle estimate sits 2.6-fold (0.42 log units) below what was measured; the measured number falls inside the stated range.
By their numbers in this assay, from the lowest: compound 2; then compound 3; then compound 1.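

In this assay, amino does not stand in for hydroxy on this saturated chain carbon bound to a carbonyl carbon, with a 4.2-fold higher number from compound 2 to compound 3 (0.62 log units; beyond the scatter), so the two groups are not interchangeable at this place. Amino still gives a lower number than bromo, with a 5.9-fold lower number from compound 1 to compound 3 (0.77 log units; beyond the scatter), which puts compound 3 in the middle of the three compounds. Nothing measured here bears on why amino and hydroxy part ways. Going by these compounds, whether a methoxy group, a carboxylic acid or a longer chain ending in hydroxy would match or beat compound 2 remains open.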